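Chain extension on the open-sugar core of compound 1

The compounds below may be only part of what the source reports. "The series", "measured", "known", "first", "only" and "open" are said of these compounds alone.

Measured compounds in this assay:
compound 1 `CCCCCc1cn([C@H]2C[C@H](O)[C@@H](CO)O2)c(=O)[nH]c1=O` gives 476 ug/mL
compound 2 `CCCCCc1cn([C@H]2C[C@@H]3OP(=O)(O)OC[C@H]3O2)c(=O)[nH]c1=O` is reported only as a limit, > 500 ug/mL
compound 3 `CCCCCCCCc1cn([C@H]2C[C@@H]3OP(=O)(O)OC[C@H]3O2)c(=O)[nH]c1=O` gives 164 ug/mL

In a functional assay on L1210 cells (Mus musculus) (a higher number here means a weaker inhibitor, a lower number a stronger inhibitor), compound 1 holds the highest of the two numbers in hand. The nearest number is that of compound 3, which lies lower, beyond the scatter. For compound 2 the assay gives only a limit and no number.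

Compound 4 `CCCCCCCCc1cn([C@H]2C[C@H](O)[C@@H](CO)O2)c(=O)[nH]c1=O` has not yet been measured. It differs from compound 1 by propyl in place of hydrogen on a saturated chain carbon, five bonds along the chain from an aromatic carbon. Going by the values given here, one measured step bears on this change: an at least 3.0-fold lower number from compound 2 to compound 3 (0.48 log units; beyond the scatter). That step is known only as a bound, due to the limit of > 500 ug/mL in this assay, at which 1 of the 3 values shown sits. The same change is now carried onto the open-sugar core of compound 1, and a lowering of similar size is expected.

For compound 4 the estimate in this assay is 160 ug/mL, with a range from 60 ug/mL to 400 ug/mL. The expected step is a 3.0-fold lower number from compound 1 to compound 4 (0.47 log units; beyond the scatter).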

Compound 4, concentration for 50% inhibition: 66 ug/mL
The estimate for compound 4 lay 2.4-fold (0.38 log units) above the measured number; measured number inside the range.
By their numbers in this assay, from the lowest: compound 4; then compound 3; then compound 1. At a limit, above all of these: compound 2.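

With both ends now measured as numbers, propyl in place of hydrogen on a saturated chain carbon, five bonds along the chain from an aromatic carbon, has a definite size in this assay: a 7.2-fold lower number from compound 1 to compound 4 (0.86 log units; beyond the scatter). The lowering is therefore seen on two cores rather than one, although its size on the first remains uncertain: the same change on two cores in this assay, an at least 3.0-fold lower number (0.48 log units; beyond the scatter) from compound 2 to compound 3 and a 7.2-fold lower number (0.86 log units; beyond the scatter) from compound 1 to compound 4; the limit leaves it open whether they differ. That uncertainty rests on a single limit, which this result does not remove: the limit of > 500 ug/mL in this assay, at which 1 of the 4 values shown sits.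

The compounds shown leave open whether a longer chain such as decyl lowers the number further in this assay or whether the trend stops. They also leave open whether a chain ending in an amine or a carboxylic acid would give a similar step on the core of compound 1.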